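The compounds below may be only part of what the source reports. "The series", "measured", "known", "first", "only" and "open" are said of these compounds alone.

Measured so far:
compound 1, `C/C(=N\NC(=O)COc1cccc2ccccc12)c1ccc(C#N)cc1Br`: 20 ug/mL
compound 2, `O=C(COc1cccc2ccccc12)N/N=C/c1cccc([N+](=O)[O-])c1`: >= 20 ug/mL

Both compounds carry the same core and were tested in an ADME assay on HEL cells (Homo sapiens) for cytotoxicity; on this read-out lower numbers stand for higher toxicity in this test and higher numbers for lower toxicity in this test. Compound 1 gives 20 ug/mL in this assay. Compound 2 gives >= 20 ug/mL in this assay, and this reading is a limit of the assay rather than a number. Compound 2 therefore stands at the limit of >= 20 ug/mL in this assay, at which 1 of the 2 values shown sits, so its true position is known only as a range beginning at that limit.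

Compound 3, `O=C(COc1cccc2ccccc12)N/N=C/c1cccc(Cl)c1`, has not yet been measured in this assay. It differs from compound 2 in one place: chloro in place of nitro on an aromatic carbon.

Among the compounds with values here, no step between two measured compounds has been recorded here, so the size of this kind of change in this assay is not known from the data. The expected effect of the change from compound 2 to compound 3 is none beyond the usual scatter of this assay.

Compound 3 is therefore expected to give about 20 ug/mL in this assay, with a range from 10 ug/mL to 40 ug/mL. That estimate corresponds to an expected step of a number no higher from compound 2 to compound 3 (the limit leaves the size open).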

Compound 3, minimum cytotoxic concentration: 100 ug/mL
For compound 3 the middle estimate is 5.0-fold (0.70 log units) below the measured one; the whole stated range lies below it.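

The step from compound 2 to compound 3 cannot be read, because compound 2 stands at a limit of the assay and not at a number: the limit of >= 20 ug/mL in this assay, at which 1 of the 3 values shown sits. The compounds shown leave open how large the effect of chloro in place of nitro on an aromatic carbon is in this assay, and in which direction it runs.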